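The source may hold more compounds than are shown below. What is called first, only, known or untested is meant among the compounds shown, and "the series" means these compounds.

In an ADME assay on HEK293 cells (Homo sapiens) for cytotoxicity, with a stated time of 72 h (a higher number here means that more compound is needed for the effect, a lower number that less compound is needed), compound 1 `Cc1cc(NC(=O)Nc2cccc(C(F)(F)F)c2)c2ccccc2n1` gives 16000 nM and compound 2 `Cc1cc(NC(=O)Nc2cccc(Cl)c2)c2ccccc2n1` gives 21000 nM in the same test, so compound 2 cannot be told apart from compound 1. Compound 3 `Cc1cc(NC(=O)Nc2cccc(C(C)(C)C)c2)c2ccccc2n1` has tert-butyl in place of chloro on an aromatic carbon. Among the measured compounds shown here, the only measured step that bears on this change is a 1.3-fold higher number from compound 1 to compound 2 (0.12 log units; within the scatter) for chloro in place of trifluoromethyl. For the measured compounds named here, the data hold no measured tert-butyl example, so no step beyond the scatter is expected in this assay here. The expected step is a 1.2-fold lower number from compound 2 to compound 3 (0.07 log units; within the scatter) and no more. Compound 3 is estimated at 18000 nM with an expected range from 8000 nM to 40000 nM overall.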

Compound 3, half-maximal effective concentration in the HEK293 assay: > 25000 nM
Compound 3 gave a limit, no number; the forecaster's own chance of this, stated with the estimate: 15%; middle value at least 1.3-fold (0.14 log units) away from the limit.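

In the HEK293 assay the result for compound 3 is a limit, not a number. Read from that limit, tert-butyl on this aromatic carbon gives an at least 1.1-fold higher number from compound 2 to compound 3 (0.07 log units; that floor lies within the scatter) and an at least 1.5-fold higher number from compound 1 to compound 3 (0.19 log units; that floor lies within the scatter), so no step in this assay beyond the scatter is established at this position. In a physicochemical assay for solubility, at pH 7.4 (on this read-out higher numbers stand for higher solubility and lower numbers for lower solubility), compound 2 gives 800 nM and compound 3 gives 34700 nM. In the physicochemical assay, however, the same change from chloro to tert-butyl shows a large step towards higher solubility: the measured solubility of compound 2, 800 nM, and of compound 3, 34700 nM, a 43-fold higher number (1.64 log units; beyond the scatter).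

Going by these compounds, how far compound 3 lies past its limit in the HEK293 assay stays open. So does how an amine or a carboxylic acid at this position would read in either assay.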